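The source may report more compounds than this note shows. Statements on the series, on what has been measured and on what is new or still open speak of the compounds shown alone.

Compound 1, `CON(C)C(=O)c1ccc(-c2ccc(OCC3CCN(C(=O)OC(C)(C)C)CC3)cn2)cc1`, gives 171 nM in a functional assay on cells for agonist activity at Glucose-dependent insulinotropic receptor (Homo sapiens), read by a luciferase reporter, with a stated time of 6 h; a lower number here means that less compound is needed, a higher number that more compound is needed for the effect.
Compound 2, `CC(C)(C)OC(=O)N1CCC(COc2ccc(-c3ccc(C(=O)N4CCCCO4)cc3)nc2)CC1`, gives 321 nM in this assay.
Compound 3, `CCc1cnc(N2CCC(COc3ccc(-c4ccc(C(=O)N(C)OC)cc4)nc3)CC2)nc1`, gives 319 nM in this assay.

Compound 3 stands second highest of these three numbers. Compound 2 sits at the same level, and compound 1 is lower, though only by a 1.9-fold higher number from compound 1 to compound 3 (0.27 log units; within the scatter), a gap that lies within the scatter of repeated measurements.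

The next compound, compound 4, `CON(C)C(=O)c1ccc(-c2ccc(OCC3CCN(C(=O)OC(C)C)CC3)cn2)cc1`, keeps the whole core of compound 3 and changes one place: isopropoxycarbonyl in place of 5-ethylpyrimidin-2-yl on an amine nitrogen in a ring. Within the data shown here, of the two measured steps, only the one from compound 1 to compound 3 touches this position; it replaced a carbamate on the ring nitrogen by the pyrimidinyl group and gave a 1.9-fold higher number from compound 1 to compound 3 (0.27 log units; within the scatter). The step from compound 1 to compound 2 alters the carbonyl end instead and says nothing about this change. Since compound 4 returns to a carbamate closely resembling that of compound 1, the step of a 1.5-fold lower number from compound 3 to compound 4 (0.18 log units; within the scatter) is expected to be small, pointing back toward compound 1 and staying within the scatter. Compound 4 is therefore estimated at 210 nM in this assay, with a range from 90 nM to 500 nM.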

Compound 4, half-maximal effective concentration: 155 nM
Compound 4: middle estimate off by 1.4-fold (0.13 log units), on the high side; the measured number falls inside the stated range.
By their numbers in this assay, from the lowest: compounds 4, 1, 3 and 2 (each within the scatter of the next, the first and the last beyond it).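

Among these compounds, on the amine nitrogen in the ring, the change to isopropoxycarbonyl from 5-ethylpyrimidin-2-yl gives a 2.1-fold lower number from compound 3 to compound 4 (0.31 log units; beyond the scatter), the first step that lies beyond the scatter, though only modestly. The earlier swap of tert-butoxycarbonyl for the same pyrimidine stayed within the scatter, so the two carbamates can now be set against the pyrimidine with slightly firmer support. Trimming the carbamate by one methyl gives a 1.1-fold lower number from compound 1 to compound 4 (0.04 log units; within the scatter), so tert-butoxycarbonyl and isopropoxycarbonyl cannot be told apart here.

Still open, on these data alone, is whether a shorter carbamate such as methoxycarbonyl, or a plain amide such as acetyl on that nitrogen, would keep the number at this level. Nothing available explains the difference between the carbamates and the pyrimidine.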